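Aryl swap on the aromatic nitrogen: compound 3 to compound 4

The source may hold more compounds than are shown below. What is called first, only, known or untested is meant among the compounds shown, and "the series" means these compounds.

In a functional assay on A549 cells (Homo sapiens) for antiproliferative activity, read by MTT assay, with a stated time of 48 h (a lower number here means a stronger inhibitor, a higher number a weaker inhibitor), compound 3 `Cc1cc(C)cc(-n2nncc2CN2C(=O)C3(C(C#N)=C(N)Oc4c(N)cc5nc6ccccc6nc5c43)c3ccccc32)c1` gives 31200 nM. Compound 2 `N#CC1=C(N)Oc2c(N)cc3nc4ccccc4nc3c2C12C(=O)N(Cc1cnnn1-c1ccccc1Cl)c1ccccc12` gives 29800 nM, and the two stand together, since a 1.0-fold higher number from compound 2 to compound 3 (0.02 log units; within the scatter). Compound 1 `N#CC1=C(N)Oc2c(N)cc3nc4ccccc4nc3c2C12C(=O)N(Cc1cnnn1-c1ccc(Cl)cc1)c1ccccc12` returns only a limit of this assay, > 50000 nM; this is the limit of > 50000 nM in this assay, at which 1 of the 3 values shown sits, not a number.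

Compound 4 `Cc1ccc(-n2nncc2CN2C(=O)C3(C(C#N)=C(N)Oc4c(N)cc5nc6ccccc6nc5c43)c3ccccc32)cc1Cl` carries 3-chloro-4-methylphenyl in place of 3,5-dimethylphenyl on an aromatic nitrogen. Three aryl swaps at this nitrogen have been measured: an at least 1.6-fold lower number from compound 1 to compound 2 (0.22 log units; that floor lies within the scatter), an at least 1.6-fold lower number from compound 1 to compound 3 (0.20 log units; that floor lies within the scatter) and a 1.0-fold higher number from compound 2 to compound 3 (0.02 log units; within the scatter), none of them resolved beyond the scatter. A further aryl swap at the same place is therefore expected to give no step beyond the scatter, a 1.0-fold lower number from compound 3 to compound 4 (0.02 log units; within the scatter). Compound 4 is estimated at 30000 nM, with a range from 12000 nM to 80000 nM.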

Compound 4, half-maximal inhibitory concentration: 11800 nM
Estimate against measurement, compound 4: 2.5-fold (0.41 log units) above, outside the stated range (below it).
By their numbers in this assay, from the lowest: compound 4; then compounds 2 and 3 (each within the scatter of the next). At a limit, above all of these: compound 1.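

At this nitrogen, an aryl swap now gives steps beyond the scatter in this assay (a modest 2.6-fold lower number from compound 3 to compound 4 (0.42 log units; beyond the scatter) and a modest 2.5-fold lower number from compound 2 to compound 4 (0.40 log units; beyond the scatter)), which sets 3-chloro-4-methylphenyl apart from the 3,5-dimethylphenyl and 2-chlorophenyl of compounds 3 and 2. Against compound 1 the step is only a floor (an at least 4.2-fold lower number from compound 1 to compound 4 (0.62 log units; beyond the scatter)), and compound 1 stands at a limit, not a number: the limit of > 50000 nM in this assay, at which 1 of the 4 values shown sits.

The compounds shown do not separate the chlorine from the methyl of 3-chloro-4-methylphenyl. Going by these compounds, how a pyridine ring or a carboxylic acid at this position would read stays open.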